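Swapping the pyridine attachment point in an M5 modulator series

The source may report more compounds than this note shows. Statements on the series, on what has been measured and on what is new or still open speak of the compounds shown alone.

Three compounds share one core, and the read-out of interest is a functional assay on CHO cells for positive allosteric modulation of muscarinic acetylcholine receptor M5 (Homo sapiens), read by FLIPR and calcium flux, with a stated time of 1 h; on this read-out lower numbers stand for smaller maximal responses and higher numbers for larger maximal responses. In this assay compound 1 `O=C1C(=O)N(Cc2ccc(-c3cccnc3)cn2)c2ccc(OC(F)(F)F)cc21` has "not determined" (no result reported), so no number is available for it. Compound 2 `O=C1C(=O)N(Cc2ccc(-c3cccnc3)cc2)c2ccc(OC(F)(F)F)cc21` gives 51% in this assay, which is the lowest of the two numbers available. Compound 3 `O=C1C(=O)N(Cc2ccc(-c3ccccc3)cc2F)c2ccc(OC(F)(F)F)cc21` gives 63% in this assay, a number that sits beyond the usual scatter above that of compound 2. Among the compounds with values here, with only two numbers in hand, no trend can be claimed from them.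

Compound 4 `O=C1C(=O)N(Cc2ccc(-c3ccncc3)cc2)c2ccc(OC(F)(F)F)cc21` has not been measured. It differs from compound 2 in a single place: pyridin-4-yl in place of pyridin-3-yl on an aromatic carbon. The two compounds contain the same atoms joined differently, so only the point at which the pyridine ring is attached changes.

Within the data shown here, no measured pair in this set shows what such a change does, so the direction of the step cannot be read from data. In this assay the step from compound 2 to compound 4 is expected to be small, likely within the scatter, at a number 4 percentage points higher from compound 2 to compound 4 (within the scatter). Compound 4 is therefore estimated at 55%, with a plausible range from 35% to 75%.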

Compound 4, largest response reached (Emax), in percent of the reference or control that the assay uses: 60%
Compound 4: middle estimate off by 5 percentage points, on the low side; the range from low to high includes it.
By their numbers in this assay, from the lowest: compounds 2, 4 and 3 (each within the scatter of the next, the first and the last beyond it).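

Swapping pyridin-3-yl for pyridin-4-yl, on an aromatic carbon para to a large group, is the first single change in this set that can be read directly. In this assay it gives a number 9 percentage points higher from compound 2 to compound 4 (within the scatter), so at this position the two attachment points cannot be told apart on maximal response. Nothing here offers a measured explanation for this result.

This finding covers only these two pyridine attachment points on this core, and one pair cannot show how far it extends. From the compounds shown here alone, it remains open whether pyridin-2-yl, or a pyridine ring carrying an amine or a carboxylic acid, would also leave the maximal response in the same range, or whether such a group would shift it beyond the usual scatter.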